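The compounds below may be only part of what the source reports. "The series", "measured", "known", "first", "only" and "open" are said of these compounds alone.

Compound 3 `Cn1nc(C(F)(F)F)cc1C(=O)Nc1ccc(S(=O)(=O)N2CCOCC2)cc1` stands at > 300000 nM in an ADME assay on Vero cells (Chlorocebus sabaeus) for cytotoxicity, read by MTT assay (on this read-out lower numbers stand for higher toxicity in this test and higher numbers for lower toxicity in this test), which is a limit and not a number. Compound 1 `Cn1nc(C(F)(F)F)cc1C(=O)Nc1ccc(S(=O)(=O)N2CCCCCC2)cc1` sits at the same limit, > 300000 nM. Among the measured compounds shown here, compound 2 `Cn1nc(C(F)(F)F)cc1C(=O)Nc1ccc(S(=O)(=O)NC2CCCCC2)cc1` gives 15000 nM, the only true number so far. Compound 4 `Cn1nc(C(F)(F)F)cc1C(=O)Nc1ccc(S(=O)(=O)N2CCCCC2C(=O)O)cc1` differs from compound 3 as follows: 2-carboxypiperidin-1-yl in place of morpholin-4-yl on a sulfonyl sulfur. The large steps of an at least 20-fold lower number from compound 1 to compound 2 (1.30 log units; beyond the scatter) and an at least 20-fold higher number from compound 2 to compound 3 (1.30 log units; beyond the scatter) both involve cyclohexylamino, which compound 4 does not carry. The closer comparison, a step that the two limits leave unreadable from compound 1 to compound 3, has limits at both ends and gives no size. No step beyond the scatter is expected in this assay because of the limit of > 300000 nM in this assay, at which 2 of the 3 values shown sit. The expected change is a number no higher from compound 3 to compound 4 (the limit leaves the size open). For compound 4 the estimated value is 300000 nM. The expected range for compound 4 runs from 80000 nM to 1000000 nM.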

Compound 4, half-maximal cytotoxic concentration: > 300000 nM
Compound 4: a limit, no number (the forecaster's own chance of this, stated with the estimate: 75%); the middle value lies on the limit itself.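

Compound 4 in this assay also gives a limit and not a number, so 2-carboxypiperidin-1-yl on the sulfonyl sulfur joins the groups that end at this limit: the limit of > 300000 nM in this assay, at which 3 of the 4 values shown sit. Cyclohexylamino remains the only group at this place with a true number, and replacing it with 2-carboxypiperidin-1-yl gives an at least 20-fold higher number from compound 2 to compound 4 (1.30 log units; beyond the scatter). The steps from compound 1 and compound 3 to compound 4 cannot be read.

From the compounds shown here alone, whether plain piperidin-1-yl, without the carboxylic acid, or cyclopentylamino would give a true number stays open. Going by these compounds, the order among compound 1, compound 3 and compound 4 also stays open.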